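Compound 3: nitro in place of amino

The source may hold more compounds than are shown below. What is called first, only, known or untested is meant among the compounds shown, and "the series" means these compounds.

In a functional assay on HEK293 cells (Homo sapiens) for cytotoxicity (on this read-out higher numbers stand for lower toxicity in this test and lower numbers for higher toxicity in this test), compound 2 (`COc1ccc([C@H]2CC(=O)N(Cc3cccc(N)c3)C2)cc1OC1CCCC1`) gives > 10000 nM, which is a limit of the assay and not a number. Compound 1 (`COc1ccc([C@H]2CC(=O)N(Cc3cccc(C#N)c3)C2)cc1OC1CCCC1`) gives > 10000 nM, also a limit. The next change leads to compound 3 (`COc1ccc([C@H]2CC(=O)N(Cc3cccc([N+](=O)[O-])c3)C2)cc1OC1CCCC1`), with nitro in place of amino on an aromatic carbon, meta to a large group (nitro in place of amino on an aromatic carbon). Among the measured compounds shown here, the one measured step bearing on this change is a step that the two limits leave unreadable from compound 1 to compound 2, so it offers no size to carry over. The expectation therefore rests on (the limit of > 10000 nM in this assay, at which 2 of the 2 values shown sit), which covers compound 1 and compound 2 alike. The expected result is a step that the limit leaves unreadable from compound 2 to compound 3, with no step beyond the scatter anticipated in this assay. For compound 3 the estimated value is 12000 nM, with an expected range of 6000 nM to 30000 nM, and a further limit is the likeliest report.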

Compound 3, half-maximal cytotoxic concentration: > 10000 nM
Compound 3 ended at the assay's limit (the forecaster's own chance of this, stated with the estimate: 85%); the middle value is on the limit's open side.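

No new step can be read among compound 1, compound 2 and compound 3 in this assay, since each value is a limit and not a number: the limit of > 10000 nM in this assay, at which 3 of the 3 values shown sit. The compounds shown leave open whether cyano, amino and nitro differ at all on this read-out.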